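Hydroxyl position on the pyridin-2-yl series

A few compounds are considered here, and "the series" means these few. Any claim that something is new, unique, unknown or untested is made for them only; others in the source may bear on it.

Compound 1 `Oc1cccc(-c2cc(-c3ccsc3)cc(-c3ccccc3O)n2)c1` gives 10.2% in an assay on isolated protein for inhibition of DNA topoisomerase 1 (Homo sapiens), with a stated time of 30 min, tested at 100 uM; a higher number here means a stronger effect of the compound at the concentration tested, a lower number a weaker effect. Compound 2 `Oc1ccc(-c2cc(-c3ccsc3)cc(-c3ccccc3O)n2)cc1` gives 13.8% in this assay; the change 4-hydroxyphenyl in place of 3-hydroxyphenyl on an aromatic carbon produced a number 3.6 percentage points higher from compound 1 to compound 2 (within the scatter). Compound 3 `Oc1cccc(-c2cc(-c3ccccn3)cc(-c3ccccc3O)n2)c1` gives 35.4% in this assay; its change from compound 1, (pyridin-2-yl in place of thiophen-3-yl on an aromatic carbon), produced a number 25.2 percentage points higher from compound 1 to compound 3 (beyond the scatter). Compound 3 holds the highest number of the three measured here.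

Compound 4 `Oc1ccc(-c2cc(-c3ccccn3)cc(-c3ccccc3O)n2)cc1` awaits measurement in this assay. It differs from compound 3 by 4-hydroxyphenyl in place of 3-hydroxyphenyl on an aromatic carbon, the same kind of change as that from compound 1 to compound 2, though the place differs: here it is meta to a pyridin-2-yl group rather than meta to a thiophen-3-yl group. Because a number 3.6 percentage points higher from compound 1 to compound 2 (within the scatter) stayed within the scatter, a step of about a number 2.6 percentage points higher from compound 3 to compound 4 (within the scatter) is expected, resting on that single precedent only. Compound 4 is accordingly estimated at 38% in this assay.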

Compound 4, a percentage reported as inhibition, at one concentration (the size of the read-out at that concentration, not a potency): 0.2%
Compound 4: middle estimate off by 37.8 percentage points, on the high side; measured number outside the range, below it.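

In this assay, 4-hydroxyphenyl in place of 3-hydroxyphenyl gives a number 35.2 percentage points lower from compound 3 to compound 4 (beyond the scatter) when pyridin-2-yl is present, so the flat result seen with thiophen-3-yl does not carry over: the same change on two cores in this assay, a number 3.6 percentage points higher (within the scatter) from compound 1 to compound 2 and a number 35.2 percentage points lower (beyond the scatter) from compound 3 to compound 4, 38.8 percentage points apart, beyond the scatter of two such steps. Pyridin-2-yl in place of thiophen-3-yl likewise gives a number 13.6 percentage points lower from compound 2 to compound 4 (beyond the scatter) with 4-hydroxyphenyl present, reversing the direction seen with 3-hydroxyphenyl: the same change on two cores in this assay, a number 25.2 percentage points higher (beyond the scatter) from compound 1 to compound 3 and a number 13.6 percentage points lower (beyond the scatter) from compound 2 to compound 4, 38.8 percentage points apart, beyond the scatter of two such steps. These four compounds show that neither change can be transferred unchanged between these cores, but they do not show why, and they give no rule for any other core.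

The compounds shown leave open whether the number of compound 3 holds when an amine or a carboxylic acid replaces the hydroxyl on the 3-hydroxyphenyl group. They also leave open what a methoxy group would do at that place.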